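The compounds below may be only part of what the source reports. "The series", "measured", "known", "first", "only" and "open" are said of these compounds alone.

Measured so far:
Compound 1, `CCCCC[Se]c1nc(NCc2ccccc2)c2ccccc2n1`, in a functional assay on CCRF-CEM cells (Homo sapiens) for cytotoxicity, read by MTT assay, with a stated time of 72 h; a lower number here means a stronger inhibitor of growth, a higher number a weaker inhibitor of growth: 34500 nM
Compound 2, `Nc1nc([SeH])nc2ccccc12`, in this assay: 25700 nM

Compound 2 shows the smaller of the two numbers, but its gap to compound 1 lies within the scatter, so the two cannot be told apart. Compound 3, `CCCCC[Se]c1nc(N)c2ccccc2n1`, carries pentyl in place of hydrogen on a selenium. Among the measured compounds shown here, no step between measured compounds isolates this change; compound 1, which also bears the pentyl on selenium, gives 34500 nM in this assay, close to compound 2. The expected change, a 1.2-fold higher number from compound 2 to compound 3 (0.07 log units; within the scatter), is therefore small, likely none beyond the scatter. Compound 3 is estimated at 30000 nM in this assay, within 10000 nM to 80000 nM.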

Compound 3, concentration for 50% growth inhibition: 34800 nM
Beside the measured number, compound 3's estimate is 1.2-fold (0.06 log units) below it; the range from low to high includes it.
By their numbers in this assay, from the lowest: compounds 2, 1 and 3 (each within the scatter of the next).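

In this assay, among the compounds shown here, pentyl in place of hydrogen on a selenium gives a 1.4-fold higher number from compound 2 to compound 3 (0.13 log units; within the scatter), the first reading of this change on its own. Hydrogen in place of benzyl on a nitrogen on an aromatic ring gives a 1.0-fold higher number from compound 1 to compound 3 (0.00 log units; within the scatter), so neither the pentyl nor the benzyl can be told from the scatter here. No supporting data bear on these results.

On these data alone, whether a longer chain such as octyl or a ring such as phenyl on the selenium would move the number beyond the scatter remains open. The same holds for an aminoethyl group in place of benzyl on the nitrogen.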